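Shortening the Nitrogen Chain in a Weakly Cytotoxic Series

The compounds below may be only part of what the source reports. "The series", "measured", "known", "first", "only" and "open" are said of these compounds alone.

Compound 2 `CCn1c(/C=C2/C(=O)Nc3ccc(Br)cc32)nc2ccccc21` carries an ethyl on its aromatic nitrogen and a bromo on an aromatic carbon. In a functional assay on A549 cells (Homo sapiens) for cytotoxicity, read by MTT assay, with a stated time of 48 h (on this read-out lower numbers stand for stronger inhibition and higher numbers for weaker inhibition), compound 2 gives only the limit > 50000 nM. Compound 3 `CCn1c(/C=C2/C(=O)Nc3ccc(C)cc32)nc2ccccc21` sits at the same limit, > 50000 nM in this assay, so the step that the two limits leave unreadable from compound 2 to compound 3 cannot be sized; both rest on (the limit of > 50000 nM in this assay, at which 2 of the 3 values shown sit). Among the compounds with values here, compound 1 `CC(C)n1c(/C=C2/C(=O)Nc3ccccc32)nc2ccccc21`, with isopropyl on the nitrogen and no ring substituent, gives 35300 nM in this assay, but it differs from compound 2 in two places, so no single measured step bears on the change to compound 4 `Cn1c(/C=C2/C(=O)Nc3ccc(Br)cc32)nc2ccccc21`, which is hydrogen in place of methyl on a saturated chain carbon bound to an aromatic nitrogen. Compound 4 is therefore expected to stay near the limit, at about 60000 nM, between 25000 nM and 150000 nM. The expected step is a step that the limit leaves unreadable from compound 2 to compound 4, with none beyond the scatter.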

Compound 4, half-maximal inhibitory concentration: 41200 nM
Compound 4: middle estimate off by 1.5-fold (0.16 log units), on the high side; the measured number falls inside the stated range.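

In this assay, within the data shown here, going from ethyl to methyl gives an at least 1.2-fold lower number from compound 2 to compound 4 (0.08 log units; that floor lies within the scatter), the first step at this position that can be given any size. With the bromo kept, the methyl compound gives a number rather than a limit, yet the change cannot be called a real gain. Its true size stays unknown, since compound 2 is held at a limit: the limit of > 50000 nM in this assay, at which 2 of the 4 values shown sit.

As far as these compounds go, whether a longer chain, an amine or a carboxylic acid on the aromatic nitrogen would move the number beyond the scatter stays open. So does the effect of this same change on compound 3.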